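Group exchange on the carbonyl, compound 1 to compound 4

The source may hold more compounds than are shown below. What is called first, only, known or untested is meant among the compounds shown, and "the series" means these compounds.

Compound 1 `Nc1ccccc1NC(=O)c1ccc(CNC(=O)c2cc3cccnc3[nH]2)cc1` gives > 100000 nM in a functional assay on MDA-MB-231 cells (Homo sapiens) for cytotoxicity, read by MTT assay, with a stated time of 72 h (a lower number here means a stronger inhibitor, a higher number a weaker inhibitor), and this is a limit, not a number. Of the two thiourea-linked neighbours, compound 2 `Nc1ccccc1NC(=O)c1ccc(NC(=S)NCc2cccnc2)cc1` has the entry "not determined" (no result reported). Going by the values given here, compound 3 `Nc1ccccc1NC(=O)c1ccc(NC(=S)NCc2cncc(F)c2)cc1` gives 85000 nM, the only actual number so far. Among the compounds with values here, its structure differs from compound 1 in more than one place, so no measured step bears on the change at hand.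

Compound 4 `Nc1ccccc1NC(=O)c1ccc(CNC(=O)c2ccc3cncn3c2)cc1` keeps the core of compound 1 and exchanges the group on a carbonyl carbon: a group of 9 heavy atoms (7 carbon, 2 nitrogen; one five-membered aromatic ring with 2 hetero atoms, one six-membered aromatic ring with 1 hetero atom) in place of a group of 9 heavy atoms (7 carbon, 2 nitrogen; one five-membered aromatic ring with 1 hetero atom, one six-membered aromatic ring with 1 hetero atom), on a carbonyl carbon. The two groups have the same atoms, joined differently.

Within the data shown here, with compound 3 at 85000 nM as the only number, a small step is expected, with no firm direction and possibly none beyond the scatter. The expected step, an at least 1.4-fold lower number from compound 1 to compound 4 (0.15 log units; that floor lies within the scatter), is an estimate and leaves a real chance of another limit. In this assay the estimate for compound 4 is 70000 nM, with an expected range of 20000 nM to 150000 nM.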

Compound 4, half-maximal inhibitory concentration: 54000 nM
Compound 4: the middle estimate sits 1.3-fold (0.11 log units) above what was measured; measured number inside the range.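

Going by these compounds alone, compound 4 gives this place, a carbonyl carbon whose other neighbours are an amide-type nitrogen, a single number in this assay, which the earlier compounds did not provide. With the same atoms joined differently, going from 1 hydrogen-bond donor and 1 acceptor to 0 donors and 2 acceptors, the exchange reads as an at least 1.8-fold lower number from compound 1 to compound 4 (0.26 log units; that floor lies within the scatter). Compound 1 has a limit and not a number, so only a floor can be read for the size of this step: the limit of > 100000 nM in this assay, at which 1 of the 4 values shown sits.

Going by these compounds, whether the result follows the ring arrangement or the donor and acceptor counts remains open, since one exchange cannot separate them. Also open, on these data alone, is how a plain phenyl group or a chain ending in a primary amine would read on the same carbonyl carbon.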